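This account rests on a few compounds, and the source may have more. Where it says the series, first, only, none or still open, it means among the compounds named here.

In a functional assay on A549 cells (Homo sapiens) for cytotoxicity, read by MTT assay, with a stated time of 72 h (a higher number here means a weaker inhibitor, a lower number a stronger inhibitor), compound 1 `COc1ccc(/C=C2\CCC/C(=C\c3ccc(O)cc3)C2=O)cc1OC` gives > 20000 nM, which is a limit of the assay and not a number. Compound 2 `COc1ccc(/C=C2\CCC/C(=C\c3cccc(Cl)c3Cl)C2=O)cc1OC` gives > 20000 nM, again only a limit, so its position in the series has no numerical value. Compound 3 `COc1ccc(/C=C2\CCC/C(=C\c3cc(Cl)cc(Cl)c3)C2=O)cc1OC` carries 3,5-dichlorophenyl in place of 2,3-dichlorophenyl on a double-bonded chain carbon bound to a double-bonded ring carbon. For the measured compounds named here, the only measured step bearing on this change is a step that the two limits leave unreadable from compound 1 to compound 2, so it supplies no size to carry over. The evidence is confined to the limit of > 20000 nM in this assay, at which 2 of the 2 values shown sit. On that basis, no step beyond the scatter and no clear direction is expected in this assay. The expected step is a number no higher from compound 2 to compound 3 (the limit leaves the size open). For compound 3 the estimated value is 20000 nM, with an expected range from 9000 nM to 40000 nM.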

Compound 3, half-maximal inhibitory concentration: 5500 nM
Beside the measured number, compound 3's estimate is 3.6-fold (0.56 log units) above it; the whole stated range lies above it.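

In this assay, this position responds to the arrangement of the chlorines alone: 3,5-dichlorophenyl in place of 2,3-dichlorophenyl, with the same atoms joined differently, gives an at least 3.6-fold lower number from compound 2 to compound 3 (0.56 log units; beyond the scatter). Against the hydroxylated ring, 3,5-dichlorophenyl in place of 4-hydroxyphenyl gives an at least 3.6-fold lower number from compound 1 to compound 3 (0.56 log units; beyond the scatter). The step from compound 1 to compound 2 cannot be read, and compound 3 is the only compound shown with a number instead of a limit: the limit of > 20000 nM in this assay, at which 2 of the 3 values shown sit.

On these data alone, how far the value of compound 3 lies from the other two compounds stays open, since both steps have only a lower bound on their size. Also open, as far as these compounds go, is whether chlorine itself matters or only the arrangement found in 3,5-dichlorophenyl, which a 3-chlorophenyl, 3,5-dimethylphenyl or 3,5-dimethoxyphenyl group, or an amine on the ring, would help to separate.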